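The source may hold more compounds than are shown below. What is called first, only, known or untested is meant among the compounds shown, and "the series" means these compounds.

Measured compounds in a functional assay on Raji cells (Homo sapiens) for inhibition, read by MTT assay, with a stated time of 48 h; on this read-out higher numbers stand for weaker inhibition and lower numbers for stronger inhibition:

Compound 1 `O=C(O)c1cn(-c2ccccc2)nc1-c1ccsc1` gives only the limit > 100000 nM.
Compound 2 `COc1ccc(OC(=O)c2cn(-c3ccccc3)nc2-c2ccsc2)cc1` gives only the limit > 100000 nM.
Compound 3 `CC(C)c1cccc(OC(=O)c2cn(-c3ccccc3)nc2-c2ccsc2)c1` gives only the limit > 100000 nM.

Compound 2 therefore stands at no number at all in this assay; it sits at the limit of > 100000 nM in this assay, at which 3 of the 3 values shown sit, and the same is true of compound 1 and compound 3, so nothing separates the three on this read-out.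

The next compound, compound 4 `O=C(Oc1ccc(-c2ccccc2)cc1)c1cn(-c2ccccc2)nc1-c1ccsc1`, differs from compound 2 in one place: phenyl in place of methoxy on an aromatic carbon.

Three steps among the measured compounds touch the same oxygen group. The step that the two limits leave unreadable from compound 1 to compound 2 and the step that the two limits leave unreadable from compound 1 to compound 3 show what happens when an aryl group replaces hydrogen there, and the step that the two limits leave unreadable from compound 2 to compound 3 compares two aryl groups, but all three run between limits and cannot be read in size or direction. No measured step therefore tells how a phenyl group in place of methoxy at the position described should move the value, and nothing among the shown compounds gives any reason to expect a reading inside the range of this assay.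

On that basis compound 4 is expected to stay at the limit, with an estimate of 100000 nM and a range from 30000 nM to 300000 nM. The expected step is a number no higher from compound 2 to compound 4 (the limit leaves the size open), no readable change from compound 2.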

Compound 4, half-maximal inhibitory concentration: > 100000 nM
Compound 4 gave a limit, no number; the forecaster's own chance of this, stated with the estimate: 80%; the middle value lies on the limit itself.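

Compound 4, like compound 2, gives only a limit in this assay, so the change from compound 2 to compound 4 cannot be read in size or direction: the limit of > 100000 nM in this assay, at which 4 of the 4 values shown sit. The compounds shown leave open whether any change to the shared core would give an actual number in this assay.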